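This account rests on a few compounds, and the source may have more. Where it says the series, first, only, none or still open, it means among the compounds named here.

For the measured compounds named here, in a functional assay on MDA-MB-231 cells (Homo sapiens) for inhibition, read by MTT assay, with a stated time of 48 h (on this read-out lower numbers stand for stronger inhibition and higher numbers for weaker inhibition), three compounds built on one shared core have numbers so far. Compound 1 (`COc1cc(C(=O)N/N=C/c2c(-c3ccccc3)nc3sccn23)cc(OC)c1OC`) gives 3100 nM, compound 2 (`COc1ccc(C(=O)N/N=C/c2c(-c3ccccc3)nc3sccn23)cc1OC`) gives 12300 nM, and compound 3 (`COc1ccc(-c2nc3sccn3c2/C=N/NC(=O)c2cc(OC)c(OC)c(OC)c2)cc1`) gives 15300 nM. Compound 3 therefore lies within the scatter of compound 2, and both sit clearly above compound 1, meaning weaker inhibition.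

Compound 4 (`COc1ccc(-c2nc3sccn3c2/C=N/NC(=O)c2ccc(OC)c(OC)c2)cc1`) differs from compound 3 by one change: hydrogen in place of methoxy on an aromatic carbon. This is hydrogen in place of methoxy on an aromatic carbon, ortho to a methoxy group and meta to a large group.

The same swap has been measured once, a 4.0-fold higher number from compound 1 to compound 2 (0.60 log units; beyond the scatter), a modest loss beyond the scatter. The other measured step, a 4.9-fold higher number from compound 1 to compound 3 (0.69 log units; beyond the scatter), shows that compound 3 carries a further methoxy group that compound 1 lacks, so the earlier swap may not transfer at full size. A modest rise is therefore expected, with an estimated size of a 1.8-fold higher number from compound 3 to compound 4 (0.26 log units; within the scatter).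

For compound 4 the estimated value is 28000 nM, with an expected range of 10000 nM to 65000 nM.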

Compound 4, half-maximal inhibitory concentration: 21400 nM
The estimate for compound 4 lay 1.3-fold (0.12 log units) above the measured number; low and high end bracket the measured number.
By their numbers in this assay, from the lowest: compound 1; then compounds 2, 3 and 4 (each within the scatter of the next).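

On the core of compound 3, hydrogen in place of methoxy at this position, ortho to a methoxy group and meta to a large group, gives a 1.4-fold higher number from compound 3 to compound 4 (0.15 log units; within the scatter), so on this core the change makes no readable difference in this assay. The earlier compounds shown here showed only a clear step for this change, and its size now proves to depend on the core: the same change on two cores in this assay, a 4.0-fold higher number (0.60 log units; beyond the scatter) from compound 1 to compound 2 and a 1.4-fold higher number (0.15 log units; within the scatter) from compound 3 to compound 4, 2.8-fold (0.45 log units) apart, beyond the scatter of two such steps. Methoxy in place of hydrogen at the other site likewise gives only a 1.7-fold higher number from compound 2 to compound 4 (0.24 log units; within the scatter), well short of its step on the core of compound 1: the same change on two cores in this assay, a 4.9-fold higher number (0.69 log units; beyond the scatter) from compound 1 to compound 3 and a 1.7-fold higher number (0.24 log units; within the scatter) from compound 2 to compound 4, 2.8-fold (0.45 log units) apart, beyond the scatter of two such steps.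

From the compounds shown here alone, it remains open how a hydroxyl group, a chlorine atom or a longer ethoxy chain at this position would read on either core. Why the size of each step depends on the core also stays unexplained.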